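The source may hold more compounds than are shown below. What is called first, only, known or untested is meant among the compounds shown, and "the series" means these compounds.

Compound 1 `CC1(C)CCC(C)(C)c2c1cc(O)c(C(=O)c1ccc3cc(C(=O)O)ccc3c1)c2F` and compound 2 `CC1(C)CCC(C)(C)c2cc(C(=O)c3ccc4cc(C(=O)O)ccc4c3)c(O)cc21` share a core and differ only in that compound 2 carries hydrogen in place of fluoro on an aromatic carbon. In an assay on isolated protein with retinoic acid receptor gamma (Homo sapiens) as the target (on this read-out lower numbers stand for smaller maximal responses and higher numbers for larger maximal responses), compound 1 gives 92%, and in this assay compound 2 gives 70%, so that the change is a number 22 percentage points lower from compound 1 to compound 2 (beyond the scatter). Going by the values given here, of the two numbers measured in this assay, compound 2 therefore stands lowest, with compound 1 its only neighbour, a number a modest step higher and beyond the scatter.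

Compound 3 `Cc1cc2c(cc1C(=O)c1ccc3cc(C(=O)O)ccc3c1)C(C)(C)CCC2(C)C` is obtained from compound 2 by the difference (methyl in place of hydroxy on an aromatic carbon). Among the compounds with values here, no measured step concerns a hydroxy group or a methyl group at this place; the one step that exists, from compound 1 to compound 2, involved a fluoro group and is a modest one. Within the data shown here, the record thus gives no direct guide, and the expectation rests on the size of the single step seen. For compound 3 a step of a number 10 percentage points lower from compound 2 to compound 3 (within the scatter) is expected, a small to modest decrease with wide uncertainty. Compound 3 is estimated to reach 60% in this assay, within a range of 30% to 90%.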

Compound 3, largest response reached (reported as maximum), in percent of the reference or control that the assay uses: 58%
The estimate for compound 3 lay 2 percentage points above the measured number, within the range that was stated.
By their numbers in this assay, from the lowest: compound 3; then compound 2; then compound 1.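

In this assay, the place on the aromatic carbon ortho to a large group now has a measured step of its own: with methyl in place of hydroxy, the change is a number 12 percentage points lower from compound 2 to compound 3 (beyond the scatter), a modest decrease. Going by these compounds alone, the only earlier step, a number 22 percentage points lower from compound 1 to compound 2 (beyond the scatter), concerned a fluoro group elsewhere on the shared core, so this result is the first to show that the maximal response also responds to the group at this place. The exchange takes away the hydrogen-bond donor and acceptor counted for hydroxy, but no accompanying measurement connects that difference with the lower number.

The compounds shown leave open how an amine, a methoxy group or a chloro atom at this same place would compare with hydroxy and methyl, and so whether hydroxy holds any special standing there. They also leave open whether methyl in place of hydroxy would give a step of similar size on the core of compound 1, which carries the fluoro group.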